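Swapping the hydroxyphenyl arm for a dimethylaminophenyl arm

The source may report more compounds than this note shows. Statements on the series, on what has been measured and on what is new or still open speak of the compounds shown alone.

Of the compounds shown here, two that share a core have been tested so far. Compound 1 `O=C1N=C(N2N=C(c3ccccc3)CC2c2ccccc2O)S/C1=C1/C(=O)Nc2ccccc21` gives 36600 nM in a functional assay on cells (Cancer cell lines, Homo sapiens) for cytotoxicity, read by sulforhodamine B assay, with a stated time of 48 h; on this read-out lower numbers stand for stronger inhibition of growth and higher numbers for weaker inhibition of growth. Compound 2 `O=C1N=C(N2N=C(c3ccccc3)CC2c2ccccc2O)S/C1=C1/C(=O)Nc2ccc(Br)cc21`, in which bromine replaces a hydrogen on an aromatic carbon, gives 940 nM in this assay, and the step of a 39-fold lower number from compound 1 to compound 2 (1.59 log units; beyond the scatter) makes compound 2 the lower of the two numbers.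

Compound 3 `CN(C)c1ccc(C2CC(c3ccccc3)=NN2C2=NC(=O)/C(=C3\C(=O)Nc4ccc(Br)cc43)S2)cc1` is not yet measured. It differs from compound 2 only in the change (4-(dimethylamino)phenyl in place of 2-hydroxyphenyl on a saturated ring carbon). For the measured compounds named here, no measured step touches this position; the one known step concerns the bromine elsewhere on the core and says nothing about the arm that is exchanged here. Since compound 2 gives 940 nM, the expectation for compound 3 is a number near it, with the step of a 1.6-fold higher number from compound 2 to compound 3 (0.20 log units; within the scatter) expected to stay within the usual scatter. Compound 3 is therefore estimated at 1500 nM, within a range from 400 nM to 6000 nM.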

Compound 3, concentration for total growth inhibition: 690 nM
For compound 3 the middle estimate is 2.2-fold (0.34 log units) above the measured one, and the stated range covers the measured number.
By their numbers in this assay, from the lowest: compounds 3 and 2 (each within the scatter of the next); then compound 1.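

In this assay, 4-(dimethylamino)phenyl in place of 2-hydroxyphenyl on the saturated ring carbon gives a 1.4-fold lower number from compound 2 to compound 3 (0.13 log units; within the scatter) and so leaves the two compounds indistinguishable. For the compounds shown here, this is the first reading at this position, and it shows that, on the bromine-bearing core, an arm with more heavy atoms and no hydrogen-bond donor can stand in for one that carries a hydroxyl, with no change beyond the scatter. Nothing at hand explains why these two arms give such similar numbers.

As far as these compounds go, with only these two arms at this position, it remains open whether a carboxylic acid on the phenyl ring, or a simple alkyl chain in place of the whole ring, would give a similar number. From the compounds shown here alone, it also remains open whether 4-(dimethylamino)phenyl would behave the same way on the core without bromine.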